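The compounds below may be only part of what the source reports. "The series", "measured", "known", "first", "only" and "open" are said of these compounds alone.

In a functional assay on CWR22R cells (Homo sapiens) for antiproliferative activity, read by propidium iodide staining, with a stated time of 96 h (on this read-out lower numbers stand for stronger inhibition and higher numbers for weaker inhibition), compound 1 `CC(O)(CS(=O)(=O)c1ccc(F)cc1)C(=O)Nc1cccc(S(F)(F)(F)(F)F)c1` gives 38900 nM and compound 2 `CC(O)(CS(=O)(=O)c1cccc(OC(F)(F)F)c1)C(=O)Nc1cccc(S(F)(F)(F)(F)F)c1` gives 20100 nM, so the two cannot be told apart. Compound 3 `CC(O)(CS(=O)(=O)c1ccccc1OC(F)(F)F)C(=O)Nc1cccc(S(F)(F)(F)(F)F)c1` differs from compound 2 as follows: 2-(trifluoromethoxy)phenyl in place of 3-(trifluoromethoxy)phenyl on a sulfonyl sulfur. Among the compounds with values here, the one measured step bearing on this also exchanges the group on the sulfonyl sulfur, a 1.9-fold lower number from compound 1 to compound 2 (0.29 log units; within the scatter). Within the data shown here, no measured compound carries 2-(trifluoromethoxy)phenyl, so nothing beyond the scatter is expected in this assay. The expected step is a 1.0-fold lower number from compound 2 to compound 3 (0.00 log units; within the scatter). Compound 3 is estimated at 20000 nM, with an expected range of 8000 nM to 50000 nM.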

Compound 3, half-maximal inhibitory concentration: 17100 nM
Compound 3: middle estimate off by 1.2-fold (0.07 log units), on the high side; low and high end bracket the measured number.
By their numbers in this assay, from the lowest: compounds 3, 2 and 1 (each within the scatter of the next, the first and the last beyond it).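

In this assay, 2-(trifluoromethoxy)phenyl in place of 3-(trifluoromethoxy)phenyl on the sulfonyl sulfur gives a 1.2-fold lower number from compound 2 to compound 3 (0.07 log units; within the scatter), so these two isomers cannot be told apart. Within the data shown here, the exchange of 4-fluorophenyl for 2-(trifluoromethoxy)phenyl gives a 2.3-fold lower number from compound 1 to compound 3 (0.36 log units; beyond the scatter), the first step at this position beyond the scatter, though a modest one. No measurement offered here explains either step. The compounds shown leave open how an unsubstituted phenyl, or a phenyl carrying an amine or a carboxylic acid, would read on the sulfonyl sulfur. They also leave open how 4-(trifluoromethoxy)phenyl would compare.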